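Isopropyl for methyl on the anilide ring of compound 2

The source may hold more compounds than are shown below. What is called first, only, known or untested is meant among the compounds shown, and "the series" means these compounds.

Compound 2 `Cc1ccc(NC(=O)c2ccc(-c3ccccn3)cc2)cc1` gives 2300 nM in a functional assay on Dorsal root ganglion for antagonist activity at transient receptor potential cation channel subfamily V member 1 (Rattus norvegicus) (on this read-out higher numbers stand for weaker inhibition and lower numbers for stronger inhibition), the highest of the three numbers recorded. Its nearest neighbour is compound 3 `Cc1ccc(NC(=O)c2ccc(-c3ccccn3)cc2)cc1C`, which gives 2000 nM, a difference within the scatter; the furthest is compound 1 `CC(C)(C)c1ccc(NC(=O)c2ccc(-c3cnccn3)cc2)cc1`, which gives 1000 nM, a gap beyond the scatter. Compound 4 `CC(C)c1ccc(NC(=O)c2ccc(-c3ccccn3)cc2)cc1` differs from compound 2 in one place: isopropyl in place of methyl on an aromatic carbon, on an aromatic carbon of a six-membered aromatic ring of carbon only, para to a large group. Within the data shown here, the only measured step on this ring, from compound 2 to compound 3, was a 1.2-fold lower number from compound 2 to compound 3 (0.06 log units; within the scatter), a change of methyl for hydrogen that left the number where it was. Among the measured compounds shown here, no measured step exchanges methyl for isopropyl, and compound 1 carries a different group on the far ring, so only its value and that of compound 2 can be set side by side. The step from compound 2 to compound 4 is therefore expected to be small, a 1.5-fold lower number from compound 2 to compound 4 (0.19 log units; within the scatter), and compound 4 is estimated at 1500 nM with a range from 600 nM to 4000 nM in this assay.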

Compound 4, half-maximal inhibitory concentration: 38 nM
Estimate against measurement, compound 4: 39-fold (1.60 log units) above, and the stated range ends above it.
By their numbers in this assay, from the lowest: compound 4; then compounds 1, 3 and 2 (each within the scatter of the next, the first and the last beyond it).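

Changing the group on this carbon, para to a large group, moves the number sharply in this assay: isopropyl in place of methyl gives a 61-fold lower number from compound 2 to compound 4 (1.78 log units; beyond the scatter), so this position responds strongly to the group it carries. Among these compounds, the only earlier step on this ring, a 1.2-fold lower number from compound 2 to compound 3 (0.06 log units; within the scatter), placed a methyl on another carbon in place of hydrogen and stayed within the scatter, so it gave no sign of a change of this size. Nothing measured here accounts for the size of the step.

On these data alone, whether an n-propyl chain, a cyclopropyl ring or a trifluoromethyl group on this carbon would match isopropyl remains open. Also open, as far as these compounds go, is whether isopropyl would give a step of this size alongside the different far ring of compound 1.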